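Amide variation on the shared core: outlook for compound 3

A few compounds are considered here, and "the series" means these few. Any claim that something is new, unique, unknown or untested is made for them only; others in the source may bear on it.

Measured compounds:
compound 1 `CNC(=O)CC1CCc2cc(OC)c(OC)cc21`: 29%
compound 2 `CCN(CC)C(=O)CC1CCc2cc(OC)c(OC)cc21`: 37.7%

In a functional assay on the whole organism (strain Wistar) for inhibition, with Rattus norvegicus as the target, read by paw edema, with stated times of 60 min and 3 h, at a dose of 100 mg/kg by the oral route (on this read-out lower numbers stand for less inhibition and higher numbers for more inhibition at the one dose given (going by the name of the read-out)), compound 2 gives 37.7%, the top of the two numbers, but only by a number 8.7 percentage points higher from compound 1 to compound 2 (within the scatter), a gap within the scatter, so compound 1 and compound 2 cannot be told apart. Compound 3 `CCCCNC(=O)CC1CCc2cc(OC)c(OC)cc21` differs from compound 2 by butylamino in place of diethylamino on a carbonyl carbon. Among the measured compounds shown here, the one step that bears on this change, a number 8.7 percentage points higher from compound 1 to compound 2 (within the scatter), is within the scatter, so no step beyond the scatter is expected in this assay. Compound 3 is therefore estimated at 33%, with a range of 22% to 45%. This means an expected step of a number 4.7 percentage points lower from compound 2 to compound 3 (within the scatter).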

Compound 3, a percentage reported as inhibition, in the whole organism at one dose (the size of the read-out at that dose, not a potency): 27.5%
Compound 3: the middle estimate sits 5.5 percentage points above what was measured; the measured number falls inside the stated range.
By their numbers in this assay, from the lowest: compounds 3, 1 and 2 (each within the scatter of the next, the first and the last beyond it).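

In this assay, among the compounds shown here, butylamino in place of diethylamino on a carbonyl carbon gives a number 10.2 percentage points lower from compound 2 to compound 3 (beyond the scatter) and thus the first step at this position beyond the scatter, although the entering group differs by carrying a hydrogen-bond donor while the heavy-atom count stays the same. Propyl in place of hydrogen on a saturated chain carbon bound to an amide-type nitrogen gives a number 1.5 percentage points lower from compound 1 to compound 3 (within the scatter) and leaves butylamino and methylamino indistinguishable. Nothing available accounts for either step.

Still open, on these data alone, is how dimethylamino, piperidine or morpholine on the same carbonyl carbon would read. As far as these compounds go, a carboxylic acid in place of the amide also remains open.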